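A few compounds are considered here, and "the series" means these few. Any claim that something is new, unique, unknown or untested is made for them only; others in the source may bear on it.

Measured compounds in the series:
compound 1 `NC1=NC2(CCOCC2)N(OCCCOc2cc(Cl)c(Cl)cc2Cl)C(N)=N1` — compound 1 gives "not determined" (no result reported) in a functional assay on HepG2 cells (Homo sapiens) for antiproliferative activity, read by MTT assay, with a stated time of 72 h; on this read-out lower numbers stand for stronger inhibition and higher numbers for weaker inhibition
compound 2 `NC1=NC2(CCOCC2)N(OCCCOc2ccc(Cl)cc2)C(N)=N1` — compound 2 gives "not determined" (no result reported) in this assay
compound 3 `NC1=NC2(CCOCC2)N(OCCCOc2ccccc2Cl)C(N)=N1` — compound 3 gives 1750 nM in this assay

Going by the values given here, compound 3 stands alone as the only member of the series with a number in this assay; compounds 1 and 2 carry no result, so no step between measured compounds can be read and nothing can be said about how the substitution pattern on the aromatic ring moves the read-out. Compound 3 is therefore the sole anchor for any expectation.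

The next compound is compound 4 `NC1=NC2(CCOCC2)N(OCCCOc2ccccc2Br)C(N)=N1`. Compared with compound 3 the difference is bromo in place of chloro on an aromatic carbon. The rest of the molecule, including the shared core and the linking chain, is unchanged.

Among the compounds with values here, with no measured step to lean on, the expectation rests only on the small size of the change. The step from compound 3 to compound 4 is expected to be small, in no particular direction, and to stay within the usual scatter of this assay.

Compound 4 is expected to give 1500 nM in this assay, with a likely range from 700 nM to 3500 nM. The implied step is estimated at a 1.2-fold lower number from compound 3 to compound 4 (0.07 log units; within the scatter), not beyond the scatter.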

Compound 4, half-maximal inhibitory concentration: 860 nM
Compound 4: the middle estimate sits 1.7-fold (0.24 log units) above what was measured, within the range that was stated.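

In this assay the series now holds its first readable step, which runs a 2.0-fold lower number from compound 3 to compound 4 (0.31 log units; beyond the scatter) with bromo in place of chloro on an aromatic carbon ortho to a large group. This shows that the read-out at this position responds to an exchange of one halogen for the other, even with the shared core and the linking chain unchanged, although the change is modest and rests on a single pair. Nothing measured here accounts for the step.

Steps involving compound 1 and compound 2 cannot be read, so the effect of the other substitution patterns on the aromatic ring remains unknown. Going by these compounds, it also remains open whether fluoro, iodo, methyl or methoxy at this place would extend the step from chloro to bromo, and whether a longer chain between the shared core and the aromatic ring would alter the read-out.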